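This account rests on a few compounds, and the source may have more. Where it says the series, first, only, none or still open, it means among the compounds named here.

Compound 2 `C[C@H](NC(=O)c1c(Cc2cccc(Cl)c2)sc2c1CCOC2)c1ccc(C(=O)O)cc1` stands lowest of the three numbers in a functional assay on CHO/Galpha16 cells for antagonist activity at prostaglandin E2 receptor EP4 subtype (Homo sapiens), read by calcium flux, with a stated time of 15 min (a higher number here means a weaker inhibitor, a lower number a stronger inhibitor), at 3.2 nM. Compound 1 `C[C@H](NC(=O)c1c(Cc2ccc(C(C)(C)C)cc2)sc2c1CCOC2)c1ccc(C(=O)O)cc1` gives 9.5 nM, and compound 3 `C[C@H](NC(=O)c1c(CCc2ccc(F)cc2)sc2c1CC(C)(C)OC2)c1ccc(C(=O)O)cc1` gives 36.2 nM. Going by the values given here, the one single-point step among the measured compounds is a 3.0-fold lower number from compound 1 to compound 2 (0.47 log units; beyond the scatter); it is the only guide to exchanging a group on this ring, and no measured step involves methoxy. Compound 4 `COc1cccc(Cc2sc3c(c2C(=O)N[C@@H](C)c2ccc(C(=O)O)cc2)CCOC3)c1` differs from compound 2 by methoxy in place of chloro on an aromatic carbon. Since the step of a 3.0-fold lower number from compound 1 to compound 2 (0.47 log units; beyond the scatter) moved the number by only a modest amount for a larger exchange on the same ring, a small shift is expected here, most likely toward a higher number. Compound 4 is therefore estimated at 6 nM, within 2.5 nM to 15 nM, a step of a 1.9-fold higher number from compound 2 to compound 4 (0.27 log units; within the scatter).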

Compound 4, half-maximal inhibitory concentration: 1.9 nM
Compound 4: middle estimate off by 3.2-fold (0.50 log units), on the high side; the whole stated range lies above it.
By their numbers in this assay, from the lowest: compounds 4 and 2 (each within the scatter of the next); then compound 1; then compound 3.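

On this aromatic carbon, chloro and methoxy cannot be told apart (a 1.7-fold lower number from compound 2 to compound 4 (0.23 log units; within the scatter)), so a group of 2 heavy atoms with a hydrogen-bond acceptor is tolerated here as well as the single chlorine. The exchange from 4-(tert-butyl)phenyl now has a second example, and 3-methoxyphenyl also stands clear of it (a 5.0-fold lower number from compound 1 to compound 4 (0.70 log units; beyond the scatter)). No measurement offered here accounts for either step.

On these data alone, whether an amine or a carboxylic acid at this ring carbon would hold the number remains open. So does whether methoxy would behave the same way on the core of compound 3.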